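The source may hold more compounds than are shown below. What is called first, only, known or untested is meant among the compounds shown, and "the series" means these compounds.

Compound 3, `Nc1nc(N)c2c(-c3ccccc3)cn([C@@H]3O[C@H](CO)[C@@H](O)[C@H]3O)c2n1`, carries a phenyl group on the five-membered aromatic ring of the shared core. In a functional assay on K562 cells (Homo sapiens), read by MTT assay, with a stated time of 72 h (a lower number here means a stronger inhibitor, a higher number a weaker inhibitor), compound 3 reaches only a limit of the assay, > 20000 nM. Compound 1, `Nc1nc(N)c2c(-c3ccsc3)cn([C@@H]3O[C@H](CO)[C@@H](O)[C@H]3O)c2n1`, bears thiophen-3-yl at the same carbon, and in this assay compound 1 likewise stops at a limit, > 20000 nM. Compound 2, `Nc1nc(N)c2c(-c3ccoc3)cn([C@@H]3O[C@H](CO)[C@@H](O)[C@H]3O)c2n1`, bears furan-3-yl there, and in this assay compound 2 also returns a limit, > 20000 nM. All three measured compounds thus sit at the same point, (the limit of > 20000 nM in this assay, at which 3 of the 3 values shown sit), so none of the three can be ranked against another.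

The step from compound 3 to compound 4 exchanges the aromatic group: furan-2-yl in place of phenyl on an aromatic carbon. The measured exchanges on this carbon, a step that the two limits leave unreadable from compound 1 to compound 2, a step that the two limits leave unreadable from compound 1 to compound 3 and a step that the two limits leave unreadable from compound 2 to compound 3, all fall between two limits, so their sizes cannot be read. None of the three shows a number below the limit, and furan-2-yl differs from furan-3-yl only in where the ring oxygen sits. It is therefore expected that the step from compound 3 to compound 4 in this assay, a step that the limit leaves unreadable from compound 3 to compound 4, is not readable beyond the scatter. Compound 4, `Nc1nc(N)c2c(-c3ccco3)cn([C@@H]3O[C@H](CO)[C@@H](O)[C@H]3O)c2n1`, is estimated to give 30000 nM in this assay, between 10000 nM and 100000 nM, most probably again as a limit rather than a number.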

Compound 4, half-maximal inhibitory concentration: > 20000 nM
Compound 4: a limit, no number; the forecaster's own chance of this, stated with the estimate: 85%; the middle value does not contradict the limit.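

In this assay compound 4 gives > 20000 nM, which is a limit and not a number, so no step from compound 1, compound 2 or compound 3 to compound 4 can be read: the limit of > 20000 nM in this assay, at which 4 of the 4 values shown sit.

The compounds shown leave open how compound 1, compound 2, compound 3 and compound 4 rank against one another, and whether any group on this aromatic carbon would give a measurable number.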